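Cyclic lactam variations and tolerated concentration in liver cells

This account rests on a few compounds, and the source may have more. Where it says the series, first, only, none or still open, it means among the compounds named here.

Measured so far:
Compound 1, `CC1CN(C(=O)Nc2cc(F)c(F)c(F)c2)Cc2c(N3CC(C#N)CC3=O)cnn21`: 115000 nM
Compound 2, `O=C1NC(c2ccccc2)CN1c1cnn2c1CN(C(=O)Nc1cc(F)c(F)c(F)c1)C(C1CC1)C2`: 38500 nM
Compound 3, `O=C1OC(c2ccccc2)CN1c1cnn2c1CN(C(=O)Nc1cc(F)c(F)c(F)c1)C(C1CC1)C2`: 7410 nM

These values come from a toxicity assay on HepG2 2.2.15 cells (Homo sapiens) for cytotoxicity, read by CellTiter-Glo; a lower number here means that less compound is tolerated, a higher number that more compound is tolerated. Compound 3 gives the lowest number of the three: compound 2 lies a 5.2-fold lower number from compound 2 to compound 3 (0.72 log units; beyond the scatter) above it, and compound 1 further still. Compound 4, `O=C1CC(c2ccccc2)CN1c1cnn2c1CN(C(=O)Nc1cc(F)c(F)c(F)c1)C(C1CC1)C2`, differs from compound 3 in one place: 2-oxo-4-phenylpyrrolidin-1-yl in place of 2-oxo-5-phenyl-1,3-oxazolidin-3-yl on an aromatic carbon. Among the compounds with values here, the only step that bears on this ring is a 5.2-fold lower number from compound 2 to compound 3 (0.72 log units; beyond the scatter), which swapped one ring hetero atom for another; here a hetero atom gives way to carbon, a change without a measured precedent. A modest step in either direction is plausible, so compound 4 is expected near compound 3, with the estimate a 1.3-fold higher number from compound 3 to compound 4 (0.13 log units; within the scatter). The expected value for compound 4 is 10000 nM, within 3000 nM to 40000 nM.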

Compound 4, half-maximal cytotoxic concentration: 12800 nM
For compound 4 the middle estimate is 1.3-fold (0.11 log units) below the measured one, within the range that was stated.
By their numbers in this assay, from the lowest: compounds 3 and 4 (each within the scatter of the next); then compound 2; then compound 1.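

In this assay carbon can take the place of the ring oxygen with no clear consequence: a 1.7-fold higher number from compound 3 to compound 4 (0.24 log units; within the scatter) separates 2-oxo-4-phenylpyrrolidin-1-yl from 2-oxo-5-phenyl-1,3-oxazolidin-3-yl by no more than repeat measurements would. The ring with a second nitrogen, 2-oxo-4-phenylimidazolidin-1-yl, is the one that stands apart, as a 3.0-fold lower number from compound 2 to compound 4 (0.48 log units; beyond the scatter) shows alongside the earlier step to the oxazolidinone. Among these three rings, then, the nitrogen-containing ring alone tolerates clearly more compound.

On these data alone, whether an amine or a carboxylic acid on the phenyl group would shift this number remains open. Nothing shown here accounts for the nitrogen-containing ring's difference.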